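A few compounds are considered here, and "the series" means these few. Any claim that something is new, unique, unknown or untested is made for them only; others in the source may bear on it.

The measured compounds in a physicochemical assay for metabolic stability, read by LC-MS, in phosphate buffer, with a stated time of 3 h, at pH 7.4, tested at 50 uM; a higher number here means that more of the compound is left, a lower number that less of the compound is left:

Compound 1 `CC(C)OC(=O)OCOC(=O)C1=C(S[C@@H]2CN[C@H](C(=O)Nc3cccc(C(=O)O)c3)C2)[C@H](C)[C@@H]2[C@@H]([C@@H](C)O)C(=O)N12` gives > 95%, which is a limit of the assay.
Compound 2 `C[C@@H](O)[C@H]1C(=O)N2C(C(=O)OCOC(=O)OC(C)(C)C)=C(S[C@@H]3CN[C@H](C(=O)Nc4cccc(C(=O)O)c4)C3)[C@H](C)[C@H]12` gives > 95%, again a limit of the assay.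
Compound 3 `C[C@@H](O)[C@H]1C(=O)N2C(C(=O)O)=C(S[C@@H]3CN[C@H](C(=O)Nc4cccc(C(=O)OCOC(=O)C(C)(C)C)c4)C3)[C@H](C)[C@H]12` gives > 95%, also a limit of the assay.

None of these three readings is a number; all of them sit at the limit of > 95% in this assay, at which 3 of the 3 values shown sit. Compound 4 `CC(C)C(=O)OCOC(=O)c1cccc(NC(=O)[C@@H]2C[C@H](SC3=C(C(=O)O)N4C(=O)[C@H]([C@@H](C)O)[C@H]4[C@H]3C)CN2)c1` has not yet been measured in this assay. It differs from compound 3 by hydrogen in place of methyl on a saturated chain carbon bound to a carbonyl carbon and two saturated chain carbons. The change from compound 2 to compound 1 is hydrogen in place of methyl on a saturated chain carbon bound to an oxygen next to a carbonyl group and two saturated chain carbons, and it gave a step that the two limits leave unreadable from compound 2 to compound 1. The two changes are the same kind of change but not the same: in compound 2 the affected carbon is bound to an oxygen next to a carbonyl group and two saturated chain carbons, whereas in compound 3 it is bound to a carbonyl carbon and two saturated chain carbons. How the core of compound 3 differs from that of compound 2 is not broken down here.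

From compound 3 to compound 4 the step is expected to be a number no higher from compound 3 to compound 4 (the limit leaves the size open), since compound 3 itself gives > 95% and both measured neighbours sit at the limit of > 95% in this assay, at which 3 of the 3 values shown sit. Compound 4 is therefore estimated at 95%, between 85% and 99%.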

Compound 4, percent of the compound remaining: > 95%
Compound 4 was reported as a limit; the forecaster's own chance of this, stated with the estimate: 70%; the middle value lies on the limit itself.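

In this assay compound 4 gives > 95%, which is a limit of the assay. Compound 3 gives > 95%, also a limit, and no step can be read between compound 3 and compound 4. The compounds shown leave open whether tert-butyl to isopropyl changes the percent remaining at all, and how the four compounds compare: the limit of > 95% in this assay, at which 4 of the 4 values shown sit.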